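The source may hold more compounds than are shown below. What is called first, only, known or untested is meant among the compounds shown, and "the series" means these compounds.

Three analogues built on a shared core were examined in a functional assay on MCF7 cells (Homo sapiens) for antiproliferative activity, read by sulforhodamine B assay, with a stated time of 72 h; a lower number here means a stronger inhibitor, a higher number a weaker inhibitor. Compound 1 `O=C1CS/C(=N/Nc2nncc3ccccc23)N1c1ccccc1` gives 77 nM there. Compound 2 `O=S(=O)(Nc1ccccn1)c1ccc(Nc2nncc3ccccc23)cc1` gives 53 nM, and compound 3 `COc1ccc(NC(=S)NNc2nncc3ccccc23)cc1` gives 60 nM. Compound 1 thus stands alongside compound 3 and compound 2, the gaps to both lying within the usual scatter of repeated measurements, so none of the three can be set apart from the others on these numbers.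

The account now turns to compound 4 `O=C1CS/C(=N/Nc2nncc3ccccc23)N1`, not yet measured, which differs from compound 1 in one place: hydrogen in place of phenyl on an amide-type nitrogen in a ring. Among the compounds with values here, no measured pair shows what this exchange does. For compound 4 a larger number than for compound 1 is nevertheless expected, in a step of modest size, a 2.6-fold higher number from compound 1 to compound 4 (0.41 log units; beyond the scatter). In this assay compound 4 is estimated at 200 nM, within a range from 70 nM to 700 nM.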

Compound 4, half-maximal inhibitory concentration: 89 nM
Beside the measured number, compound 4's estimate is 2.2-fold (0.35 log units) above it, within the range that was stated.
By their numbers in this assay, from the lowest: compounds 2, 3, 1 and 4 (each within the scatter of the next).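

Within the data shown here, the step gives the first direct reading at this position: on the amide-type nitrogen in a ring, hydrogen in place of phenyl gives, in this assay, a 1.2-fold higher number from compound 1 to compound 4 (0.06 log units; within the scatter). For this pair, then, the phenyl group with its six carbon atoms can be removed without a difference that can be told from the scatter. No available evidence speaks to why this is so. The compounds shown leave open whether a methyl group, a longer alkyl chain or a carboxylic acid on this nitrogen would also leave the number within the scatter.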